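Swapping Methyl for Fluoro on the Benzyl Group

The source may hold more compounds than are shown below. What is called first, only, known or untested is meant among the compounds shown, and "the series" means these compounds.

Compound 1 `C=C(Br)C(=O)Nc1cccc(/C=C2\SC(=O)N(Cc3ccc(C)cc3)C2=O)c1` carries a bromoacrylamide on one aromatic ring and a 4-methylbenzyl group on the nitrogen of the shared core. In a functional assay on HeLa cells (Homo sapiens) for cytotoxicity, read by cell counting, with a stated time of 4 days (a higher number here means a weaker inhibitor, a lower number a stronger inhibitor), compound 1 gives 1200 nM. Among the numbers shown this is the higher of two, and the nearest is compound 3 `C=C(Br)C(=O)Nc1ccc(/C=C2\SC(=O)N(Cc3ccccc3)C2=O)cc1`, which gives 1000 nM in this assay; the gap between them lies within the usual scatter of repeated measurements, so the two cannot be ranked. Compound 2 `Nc1cccc(/C=C2\SC(=O)N(Cc3cccc(F)c3)C2=O)c1`, in which an amine stands where the bromoacrylamide sits in the other two, reaches only a limit of this assay, > 250000 nM, meaning no number could be read for it (the limit of > 250000 nM in this assay, at which 1 of the 3 values shown sits).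

Compound 4 `C=C(Br)C(=O)Nc1cccc(/C=C2\SC(=O)N(Cc3ccc(F)cc3)C2=O)c1` differs from compound 1 in one place: fluoro in place of methyl on an aromatic carbon. Among the measured compounds shown here, no measured pair in this set shows the same change, so its size is not known from the data. A small step is expected, no change at the digits printed from compound 1 to compound 4 (within the scatter), in either direction and not beyond the scatter. Compound 4 is therefore estimated at 1200 nM in this assay, with a range from 500 nM to 3000 nM.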

Compound 4, half-maximal inhibitory concentration: 800 nM
Beside the measured number, compound 4's estimate is 1.5-fold (0.18 log units) above it; the range from low to high includes it.
By their numbers in this assay, from the lowest: compounds 4, 3 and 1 (each within the scatter of the next). At a limit, above all of these: compound 2.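

In this assay, among the compounds shown here, the pair gives the first step in this set where only one place differs, and it reads a 1.5-fold lower number from compound 1 to compound 4 (0.18 log units; within the scatter). With the rest of compound 1 held fixed, methyl and fluoro on this aromatic carbon, para to a large group, give numbers that cannot be told apart, so this position accepts either group with no change that can be separated from ordinary assay noise. Nothing measured here accounts for that likeness between the two groups.

As far as these compounds go, whether this holds only for small groups stays open: a methoxy group, a trifluoromethyl group, a longer chain such as ethyl or a plain hydrogen at the same position could each behave differently, and one pair cannot set a trend for the position. The part played by the bromoacrylamide also stays open, since compound 2, the only compound shown without it, also differs from compound 1 and compound 4 on the benzyl group, so its amine cannot be compared with the bromoacrylamide on its own.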